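This account rests on a few compounds, and the source may have more. Where it says the series, first, only, none or still open, it means among the compounds named here.

Of the compounds shown here, two have so far been measured in an assay on HEK-293T cells for inhibition of phospholipase A and acyltransferase 3 (Homo sapiens), with stated times of 30 min and 20 min; a lower number here means a stronger inhibitor, a higher number a weaker inhibitor. Compound 1 `O=C(NCc1ccccc1)C(F)(F)C(O)CCc1ccccc1` gives only a limit of > 10000 nM in this assay. Compound 2 `O=C(CCc1ccc(Cl)cc1)C(=O)N1CCCCC1` also gives only a limit of > 10000 nM in this assay, which places it at the same edge of the measured range as the other compound (the limit of > 10000 nM in this assay, at which 2 of the 2 values shown sit). Compound 3 `O=C(CCc1ccc(Cl)cc1)C(=O)N1CCCC1` differs from compound 2 in one place: pyrrolidin-1-yl in place of piperidin-1-yl on a carbonyl carbon. Within the data shown here, no measured pair shows how such a change moves the number in this assay. The change is expected to shift the number by no more than the usual scatter a step that the limit leaves unreadable from compound 2 to compound 3. Compound 3 is therefore expected to give about 15000 nM in this assay, within 4000 nM to 50000 nM.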

Compound 3, half-maximal inhibitory concentration: > 10000 nM
Compound 3: only a limit was reported; the forecaster's own chance of this, stated with the estimate: 80%; the middle value does not contradict the limit.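

Among these compounds, compound 2 and compound 3 each give only a limit in this assay, so no step between them can be read: the limit of > 10000 nM in this assay, at which 3 of the 3 values shown sit. The compounds shown leave open how strongly any of them inhibits, and which structural change would yield a measurable number.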